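This account rests on a few compounds, and the source may have more. Where it says the series, first, only, none or still open, it means among the compounds named here.

Measured compounds:
compound 1 `CCCC(=O)OCC1CN(C(=O)c2cc(OC)c(OC)c(OC)c2)CCN1C(=O)c1cc(OC)c(OC)c(OC)c1` — 420 nM
compound 2 `COc1cc(C(=O)N2CCN(C(=O)c3cc(OC)c(OC)c(OC)c3)C(COC(=O)C(C)(C)C)C2)cc(OC)c1OC` — 100 nM; 100 nM; 120 nM (3 entries)

This account follows the step from compound 1 to compound 3 in a functional assay (Oryctolagus cuniculus) for inhibition of platelet-activating factor receptor (Cavia porcellus); a higher number here means a weaker inhibitor, a lower number a stronger inhibitor. Within the data shown here, compound 1 is the one compound with a single number in this assay; a further entry for compound 1 carries no single number. The value of compound 1, 420 nM, lies well above what compound 2 shows, where the several entries of compound 2 (the several entries of compound 2 in this assay, 100 nM; 100 nM; 120 nM (3 entries)) sit close together. Among the measured compounds shown here, no step between measured compounds that differ in one place is known, so the size of the step to compound 3 has to be expected rather than read off from a measured pair.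

Compound 3 `COc1cc(C(=O)N2CCN(C(=O)c3cc(OC)c(OC)c(OC)c3)C(COC(=O)NC(C)C(C)(C)C)C2)cc(OC)c1OC` has not yet been measured in this assay. It differs from compound 1 in one place: (1,2,2-trimethylpropyl)amino in place of propyl on a carbonyl carbon. Without a measured step of this kind, the expectation rests on the two values shown and on the change itself. The step from compound 1 to compound 3 in this assay is expected to be modest and toward a stronger inhibitor, a 2.1-fold lower number from compound 1 to compound 3 (0.32 log units; beyond the scatter), though a result within the scatter of compound 1 would not surprise. Compound 3 is therefore estimated at 200 nM, with a range from 60 nM to 700 nM.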

Compound 3, half-maximal inhibitory concentration: 170 nM
Compound 3: the middle estimate sits 1.2-fold (0.07 log units) above what was measured; low and high end bracket the measured number.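

In this assay, putting (1,2,2-trimethylpropyl)amino in place of propyl on this carbonyl carbon gives a 2.5-fold lower number from compound 1 to compound 3 (0.39 log units; beyond the scatter). This pair shows that the group at this place can grow from 3 heavy atoms to 7 and gain 1 hydrogen-bond donor with no loss of inhibition, and with a number that moves toward a stronger inhibitor. The step is modest, but repeat readings in this assay can lie close together, as another compound on the same core shows: the several entries of compound 2 in this assay, 100 nM; 100 nM; 120 nM (3 entries)

Among these compounds, still, the single pair changes the nitrogen and the branched carbon chain at once, so it cannot say which of the two carries the difference. The compounds shown leave open how a simple methylamino, a dimethylamino or a cyclohexylamino group would read at this carbonyl carbon, which would begin to separate the two. They also leave open what a longer chain ending in a carboxylic acid would do at the same place in this assay.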